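Chloro in place of methyl: notes on four compounds

The source may report more compounds than this note shows. Statements on the series, on what has been measured and on what is new or still open speak of the compounds shown alone.

Measured in a functional assay on NCI-H226 cells (Homo sapiens) for inhibition, read by MTT assay, with a stated time of 72 h; on this read-out higher numbers stand for weaker inhibition of growth and lower numbers for stronger inhibition of growth:
compound 1, `Cc1ccc(-c2cc(/N=C/N(C)C)n(-c3ccc(Br)cc3)n2)cc1`, 73900 nM
compound 2, `CN(C)/C=N/c1cc(-c2ccc(Cl)cc2)nn1-c1ccc(Br)cc1`, 59800 nM
compound 3, `Cc1ccc(-c2nn(-c3ccc(Br)cc3)c(N)c2C=O)cc1`, 8500 nM

The step of a 1.2-fold lower number from compound 1 to compound 2 (0.09 log units; within the scatter) comes from the change (chloro in place of methyl on an aromatic carbon). Compound 3 gives the lowest of the three numbers; compound 2 is nearest and compound 1 furthest, both gaps beyond the scatter. The difference between the core of compound 3 and the core of compound 1 is not broken down here.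

Compound 4, `Nc1c(C=O)c(-c2ccc(Cl)cc2)nn1-c1ccc(Br)cc1`, has not been measured in this assay. It differs from compound 3 by chloro in place of methyl on an aromatic carbon, the same change as from compound 1 to compound 2, at a place described in the same words. The expected step of a 1.2-fold lower number from compound 3 to compound 4 (0.08 log units; within the scatter) rests on a 1.2-fold lower number from compound 1 to compound 2 (0.09 log units; within the scatter), which lies within the scatter. In this assay compound 4 is estimated at 7000 nM, expected between 3000 nM and 18000 nM.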

Compound 4, concentration for 50% growth inhibition: 49100 nM
Compound 4: the middle estimate sits 7.0-fold (0.85 log units) below what was measured, and the stated range ends below it.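

Chloro in place of methyl gives a 5.8-fold higher number from compound 3 to compound 4 (0.76 log units; beyond the scatter) in this assay, which means weaker inhibition of growth, while the same change on the core of compound 1 gives no step beyond the scatter. The change therefore does not carry over unchanged between these two cores: the same change on two cores in this assay, a 1.2-fold lower number (0.09 log units; within the scatter) from compound 1 to compound 2 and a 5.8-fold higher number (0.76 log units; beyond the scatter) from compound 3 to compound 4, 7.1-fold (0.85 log units) apart, beyond the scatter of two such steps
Among the compounds shown here, with only one pair on each core, this shows that the size of the step differs between the two cores, but not which feature of the cores accounts for it or how the change would behave on a further core.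

From the compounds shown here alone, whether the step on the core of compound 3 is particular to chloro remains open. A fluoro group, a methoxy group or an amine in the same place on both cores would address this.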